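Ethyl Ester of an Acid Probe in a Cytotoxicity Screen

The compounds below may be only part of what the source reports. "The series", "measured", "known", "first", "only" and "open" are said of these compounds alone.

Compound 1 `CC(C)N(Cc1cccc(OCCCCCC(=O)O)c1)C(=O)c1ccc(-c2ccoc2)cc1` gives > 26000 nM in an ADME assay on Raji cells (Homo sapiens) for cytotoxicity, read by CellTiter-Glo and resazurin assay, with a stated time of 72 h (on this read-out higher numbers stand for an effect only at larger amounts of compound and lower numbers for an effect already at smaller amounts), a limit of the assay rather than a number.
Compound 2 `COc1cc(F)cc(-c2ccc(C(=O)N(Cc3cccc(OCCCCCC(=O)O)c3)C(C)C)cc2)c1` gives > 26000 nM in this assay, again a limit.
Compound 3 `CC(C)N(Cc1cccc(OCCCCCC(=O)O)c1)C(=O)c1ccc(-c2cccc(Br)c2)cc1` gives > 26000 nM in this assay, also a limit.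

All three measured compounds share one core and differ only in the group on an aromatic carbon. Each of them sits at the limit, as the limit of > 26000 nM in this assay, at which 3 of the 3 values shown sit, records, so compound 1 stands nowhere below or above its companions; it is simply one of three values that are limits. The steps between them, a step that the two limits leave unreadable from compound 1 to compound 2, a step that the two limits leave unreadable from compound 1 to compound 3 and a step that the two limits leave unreadable from compound 2 to compound 3, are unreadable for the same reason, and they say nothing about how much room there is beyond the limit.

Compound 4 `CCOC(=O)CCCCCOc1cccc(CN(C(=O)c2ccc(-c3ccoc3)cc2)C(C)C)c1` is the next compound. It differs from compound 1 by ethyl in place of hydrogen on an oxygen next to a carbonyl group. Among the measured compounds shown here, none of the measured steps touches this part of the molecule; they all concern the group on the aromatic carbon, and all three are unreadable, so no step of known size bears on the change from compound 1 to compound 4. The expectation therefore rests on the three limits alone: a further limit, or a value in its neighbourhood, with no direction that can be read from the data. Compound 4 is estimated to give 26000 nM, with a range from 9000 nM to 80000 nM. The step from compound 1 to compound 4 that this estimate means, a number no higher from compound 1 to compound 4 (the limit leaves the size open), is expected to stay within the scatter.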

Compound 4, half-maximal effective concentration: > 26000 nM
Compound 4 was reported as a limit; the forecaster's own chance of this, stated with the estimate: 75%; the middle value sits exactly at the limit.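

In this assay compound 4 gives > 26000 nM as a limit of the assay. Compound 1 is also reported only as a limit, so no step between compound 1 and compound 4 can be read, and the four compounds stand together: the limit of > 26000 nM in this assay, at which 4 of the 4 values shown sit.
The compounds shown leave open how far beyond this limit each one lies, and so what ethyl in place of hydrogen changes here.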